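Working notes: cyano in place of fluoro, compound 4

The source may hold more compounds than are shown below. What is called first, only, known or untested is meant among the compounds shown, and "the series" means these compounds.

Measured in an ADME assay on J774 cells (Mus musculus) for cytotoxicity, read by MTT assay, with a stated time of 48 h, tested at 150 ug/mL; a lower number here means a stronger effect, a higher number a weaker effect of the compound at the concentration tested:
compound 1 `O=C(N/N=C/c1ccccc1Cl)c1cnccn1` gives 69%
compound 2 `O=C(N/N=C/c1cccc(F)c1)c1cnccn1` gives 40%
compound 3 `N#Cc1ccccc1/C=N/NC(=O)c1cnccn1` gives 70%

Compound 2 shows the lowest of the three numbers; compound 1 and compound 3 both stand well above it, beyond the scatter, and those two lie close to each other.

Compound 4 `N#Cc1cccc(/C=N/NC(=O)c2cnccn2)c1` has not yet been measured. It differs from compound 2 as follows: cyano in place of fluoro on an aromatic carbon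

Going by the values given here, only one measured step bears on this change. Compound 1 and compound 3 share the swap of a halogen for a cyano group on the same aromatic ring, and there a number 1 percentage points higher from compound 1 to compound 3 (within the scatter). That step, however, replaces chloro rather than fluoro and sits at a different place on the ring, so it is not a direct guide. Nothing measured shows what fluoro contributes on its own.

Given that the halogen-to-cyano step between compound 1 and compound 3 left the number essentially unchanged, while compound 2 stands clearly below both, the expectation for compound 4 is a number that moves back up toward the other two members but stays uncertain. Compound 4 is estimated to give 52%, with a range from 32% to 72%. This expected change means a number 12 percentage points higher from compound 2 to compound 4 (beyond the scatter).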

Compound 4, a percentage reported as activity, at one concentration (the size of the read-out at that concentration, not a potency): 100%
Estimate against measurement, compound 4: 48 percentage points below; the whole stated range lies below it.
By their numbers in this assay, from the lowest: compound 2; then compounds 1 and 3 (each within the scatter of the next); then compound 4.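

In this assay the change from fluoro to cyano meta to a large group gives a number 60 percentage points higher from compound 2 to compound 4 (beyond the scatter) and so marks this ring place as highly sensitive to the swap. The earlier halogen-to-cyano step, in which chloro left from another place on the ring, gives a number 1 percentage points higher from compound 1 to compound 3 (within the scatter) and stays within the scatter, so across these two pairs the swap has no single size and the outcome depends on the halogen that leaves, its place, or both. No measurement shown accounts for the size of the new step.

The compounds shown leave open whether the large step reflects something cyano adds at this place or something fluoro contributes there, since neither group is compared with a plain hydrogen at the same carbon. It also remains to be seen where an amine, a methoxy group or a carboxylic acid meta to a large group would fall on this scale, and whether any of these would track fluoro, cyano or neither.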